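Working notes: opening the sulfur ring of compound 2

This account rests on a few compounds, and the source may have more. Where it says the series, first, only, none or still open, it means among the compounds named here.

- compound 1 (`CC(=O)SCCC(CCCCC(=O)O)SC(C)=O`): 1.61%
- compound 2 (`O=C(CCCCC1CCSS1)Nc1ccc(OC(F)(F)F)cc1`): 8.57%

Both values come from a functional assay on HO8910 cells (Homo sapiens) for inhibition, read by MTT assay, with a stated time of 24 h, tested at 10 ug/mL (on this read-out higher numbers stand for more inhibition of growth at the one concentration tested and lower numbers for less inhibition of growth), and lie within the usual scatter of each other. Compound 2 therefore stands level with compound 1, and no order can be read between them. Among the compounds with values here, the two compounds differ in more than one place, so the series offers no measured single-change step to guide the next comparison.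

Compound 3 (`O=C(CCCCC(S)CCS)Nc1ccc(OC(F)(F)F)cc1`) differs from compound 2 in one place, and the rest of the structure stays the same. The change is a group of 5 heavy atoms (3 carbon, 2 sulfur; no ring) in place of a group of 5 heavy atoms (3 carbon, 2 sulfur; one five-membered non-aromatic ring with 2 hetero atoms), on a saturated chain carbon, four bonds along the chain from a carbonyl carbon and it replaces the ring with an open chain.

In this assay a step no larger than the scatter is expected, with a slight upward lean. This expectation rests only on compound 2 at 8.57% and compound 1 at 1.61% as the two available readings, so it remains loose. The estimated step is a number 4.4 percentage points higher from compound 2 to compound 3 (within the scatter) and it stays within the scatter. For compound 3 the expected value is 13% with an expected range from 2% to 30% on this estimate.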

Compound 3, percent growth inhibition at one concentration: 6.11%
Compound 3: middle estimate off by 6.9 percentage points, on the high side, and the stated range covers the measured number.
By their numbers in this assay, from the lowest: compounds 1, 3 and 2 (each within the scatter of the next).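

Opening the one five-membered non-aromatic ring with 2 hetero atoms to 1,3-disulfanylpropyl, on a saturated chain carbon, four bonds along the chain from a carbonyl carbon, gives the series its first measured single-change step: in this assay the result is a number 2.5 percentage points lower from compound 2 to compound 3 (within the scatter) for this change. At this position, the ring and the open chain therefore cannot be told apart in this assay even though the group that enters carries 2 hydrogen-bond donors and the group that leaves carries 0, so this single step gives no sign that the closed ring matters for the read-out. No measurement at hand bears on why the two forms read alike.

On these data alone, whether a different group at the same place, such as a 1,3-dihydroxypropyl group or a simple amine, would move the reading beyond the scatter remains open. As far as these compounds go, it is also open whether the ring and the open chain would still read alike with an ester in place of the amide of the shared core.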